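From 3-methylphenyl to 2,6-dimethoxyphenyl on the shared core

The source may report more compounds than this note shows. Statements on the series, on what has been measured and on what is new or still open speak of the compounds shown alone.

Measured so far in a functional assay on HOS-TE85 cells (Homo sapiens) for inhibition, read by CCK-8 assay, with a stated time of 72 h; a lower number here means a stronger inhibitor, a higher number a weaker inhibitor
- compound 1 `COc1ccccc1N1C(=O)CSC1c1cc(C(=O)NCCCCc2ccccc2)cc(C2CC2)c1` gives 23.5 nM
- compound 2 `Cc1cccc(N2C(=O)CSC2c2cccc(C(=O)NCCCCc3ccccc3)c2)c1` gives 93.2 nM
- compound 3 `CCOC(=O)c1sc(N2C(=O)CSC2c2cccc(C(=O)NCCCCn3cccn3)c2)nc1C` gives 430 nM

Compound 2 holds the second highest of the three numbers, with compound 1 lower and compound 3 higher, and both gaps lie beyond the scatter. Compound 4 `COc1cccc(OC)c1N1C(=O)CSC1c1cccc(C(=O)NCCCCc2ccccc2)c1` carries 2,6-dimethoxyphenyl in place of the 3-methylphenyl of compound 2 on an amide-type nitrogen in a ring (2,6-dimethoxyphenyl in place of 3-methylphenyl on an amide-type nitrogen in a ring). Going by the values given here, no measured pair isolates this change, which leaves the expectation loose. Among the compounds with values here, the only measured support is compound 1, which also bears a methoxy group on its phenyl and has the lowest number of the three (23.5 nM). A small expected move toward a stronger inhibitor in this assay follows (a 1.6-fold lower number from compound 2 to compound 4 (0.19 log units; within the scatter)), one that would stay within the scatter. For compound 4 the estimated value is 60 nM (expected range 15 nM to 240 nM).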

Compound 4, half-maximal inhibitory concentration: > 1000 nM
Compound 4: a limit, no number; the forecaster's own chance of this, stated with the estimate: 3%; at least 16-fold (1.22 log units) between middle value and limit.
By their numbers in this assay, from the lowest: compound 1; then compound 2; then compound 3. At a limit, above all of these: compound 4.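

Going by these compounds alone, replacing 3-methylphenyl with 2,6-dimethoxyphenyl on the amide-type nitrogen in a ring gives an at least 10-fold higher number from compound 2 to compound 4 (1.03 log units; beyond the scatter), the first step to isolate a single place, read in this assay. Compound 4 stands at > 1000 nM, which is a limit and not a number. This position therefore does not accept every substituted phenyl alike, and the full size of the step remains unresolved at its upper end: the limit of > 1000 nM in this assay, at which 1 of the 4 values shown sits.

Still open, going by these compounds, is whether the loss goes with the methoxy groups themselves or with the places they occupy on the phenyl; a compound with methyl in place of each methoxy group of compound 4 would separate the two. Compound 1 also carries a methoxy-bearing phenyl but differs from compound 4 in more than one place, so it does not settle this question.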